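Chloro to cyano on the sulfonate aryl ring

The compounds below may be only part of what the source reports. "The series", "measured", "known", "first", "only" and "open" are said of these compounds alone.

Compound 1, `CNC(=O)/C=C1/COc2cc(OS(=O)(=O)c3ccccc3)ccc21`, is the unsubstituted parent of this pair; in an assay (strain Sprague-Dawley) for inhibition of Amine oxidase [flavin-containing] A (Rattus norvegicus), read by spectrophotometry, with a stated time of 5 min (a lower number here means a stronger inhibitor, a higher number a weaker inhibitor), compound 1 gives 34 nM. Compound 2, `CNC(=O)/C=C1/COc2cc(OS(=O)(=O)c3cccc(Cl)c3)ccc21`, carries chloro on the aryl ring of the sulfonate; in this assay compound 2 gives 41 nM. Among the compounds with values here, the single measured step, a 1.2-fold higher number from compound 1 to compound 2 (0.08 log units; within the scatter), is the only comparison available, and it shows that adding chloro at this position leaves the number essentially where it was. Compound 2 therefore stands with the higher of the two numbers, yet within the scatter of compound 1.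

Compound 3, `CNC(=O)/C=C1/COc2cc(OS(=O)(=O)c3cccc(C#N)c3)ccc21`, differs from compound 2 by cyano in place of chloro on an aromatic carbon. Within the data shown here, no measured step involves cyano anywhere, so the only guide is the step from hydrogen to chloro at the same position, which was within the scatter. A substituent change at a position that tolerated chloro without a shift beyond the scatter is expected to give at most a modest change here as well, in either direction.

The step from compound 2 to compound 3 is estimated as a 1.1-fold higher number from compound 2 to compound 3 (0.04 log units; within the scatter). Compound 3 is expected to give 45 nM in this assay, with a range from 18 nM to 110 nM.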

Compound 3, half-maximal inhibitory concentration: 19 nM
The estimate for compound 3 lay 2.4-fold (0.37 log units) above the measured number; the measured number falls inside the stated range.
By their numbers in this assay, from the lowest: compounds 3, 1 and 2 (each within the scatter of the next, the first and the last beyond it).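

In this assay, within the data shown here, the exchange of chloro for cyano at this place on the sulfonate aryl ring, meta to a large group, gives the first step that passes the scatter: a 2.2-fold lower number from compound 2 to compound 3 (0.33 log units; beyond the scatter) is what separates the two substituted compounds. Set against the unsubstituted parent, the same group gives a 1.8-fold lower number from compound 1 to compound 3 (0.25 log units; within the scatter), which stays inside the scatter, so compound 1 sits within the scatter of both substituted compounds and only the chloro and cyano pair can be told apart. Nothing available on this series bears on why these two groups part at this position.

With only hydrogen, chloro and cyano shown at this place, it remains open whether a carboxylic acid, an amine or a methoxy group would extend the separation seen here or reverse it. Also open, going by these compounds, is whether the gap between cyano and chloro would hold with either group elsewhere on the same ring, or with a longer chain in place of the methyl on the amide of the shared core.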